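A few compounds are considered here, and "the series" means these few. Any claim that something is new, unique, unknown or untested is made for them only; others in the source may bear on it.

In a functional assay on SK-BR-3 cells (Homo sapiens) for antiproliferative activity (on this read-out higher numbers stand for weaker inhibition and lower numbers for stronger inhibition), compound 1 (`CC(C)=CCc1cc(C(=O)Nc2cc3ccc(OCCCNC4CCCCC4)c(C)c3oc2=O)ccc1O`) gives 660 nM. Compound 2 (`CC(C)=CCc1cc(C(=O)Nc2cc3ccc(OCCCNc4ccccc4)c(C)c3oc2=O)ccc1O`) carries phenyl in place of cyclohexyl on the amine nitrogen. For compound 2 the assay returns only a limit, > 50000 nM. It therefore stands at the limit of > 50000 nM in this assay, at which 1 of the 2 values shown sits, and no exact number is available for it.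

Compound 3 (`CC(C)=CCc1cc(C(=O)Nc2cc3ccc(OCCCN(C)c4ccccc4)c(C)c3oc2=O)ccc1O`) differs from compound 2 by methyl in place of hydrogen on a nitrogen on an aromatic ring, so that anilino becomes methyl(phenyl)amino. For the measured compounds named here, no measured step makes this exchange. The nearest evidence is an at least 75-fold higher number from compound 1 to compound 2 (1.87 log units; beyond the scatter), a large change at the same nitrogen. Compound 3 keeps the phenyl introduced in that step, so a recovery of that size in this assay is not expected. Only a small step is expected, and since compound 2 has only a limit, that step can point only toward a lower number. The estimate corresponds to an expected at least 1.2-fold lower number from compound 2 to compound 3 (0.09 log units; that floor lies within the scatter). For compound 3 the expected value is 40000 nM, with an estimated range of 8000 nM to 100000 nM.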

Compound 3, half-maximal inhibitory concentration: > 50000 nM
Compound 3 gave a limit, no number; the forecaster's own chance of this, stated with the estimate: 60%; middle value at least 1.2-fold (0.09 log units) from the limit.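

In this assay compound 3 returns only a limit, > 50000 nM, and not a number. Exchanging cyclohexylamino for methyl(phenyl)amino on the saturated chain carbon gives an at least 75-fold higher number from compound 1 to compound 3 (1.87 log units; beyond the scatter), so methyl on the nitrogen on an aromatic ring does not bring a phenyl-bearing amine back to a measurable value in this assay. The step that adds this methyl cannot be read, since compound 2 and compound 3 both end at a limit, and the two phenyl-bearing amines can be placed in no order: the limit of > 50000 nM in this assay, at which 2 of the 3 values shown sit.

The compounds shown leave open whether the loss of activity follows the phenyl standing directly on the nitrogen or the loss of the cyclohexyl ring, a question that a benzylamino or a cyclopentylamino group at the end of the same chain would bear on. They also leave open what methyl on this nitrogen does while the cyclohexyl stays in place, as in a methyl(cyclohexyl)amino group, where a measured number on both sides of the step could be read.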